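Tetrazolyl in Place of Pyrazolyl on the Phenyl Ring

The source may report more compounds than this note shows. Statements on the series, on what has been measured and on what is new or still open speak of the compounds shown alone.

Of the compounds shown here, two of a shared core have been measured. In a functional assay on HEK293 cells for agonist activity at Bombesin receptor subtype-3 (Mus musculus), read by luminescence and calcium flux, with a stated time of 10 min (on this read-out higher numbers stand for an effect only at larger amounts of compound and lower numbers for an effect already at smaller amounts), compound 1 `CCC(C)(C)Cc1c[nH]c(CCc2ccc(-c3ccncc3)cc2)n1` gives 103 nM. Compound 2 `CCC(C)(C)Cc1c[nH]c(CCc2ccc(-n3cccn3)cc2)n1` gives 113 nM in this assay. On the numbers shown compound 2 stands beside compound 1, the two within the scatter of each other, so neither stands apart.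

Compound 3 `CCC(C)(C)Cc1c[nH]c(CCc2ccc(-n3ncnn3)cc2)n1` is not yet measured. It differs from compound 2 by 2H-tetrazol-2-yl in place of 1H-pyrazol-1-yl on an aromatic carbon. Among the compounds with values here, only one measured step bears on this kind of exchange of the aromatic group at that place: a 1.1-fold higher number from compound 1 to compound 2 (0.04 log units; within the scatter), which was within the scatter. On that basis no step beyond the scatter is expected, and the estimated step is a 1.2-fold higher number from compound 2 to compound 3 (0.06 log units; within the scatter). Compound 3 is therefore expected to give about 130 nM in this assay, with an estimated range from 40 nM to 400 nM.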

Compound 3, half-maximal effective concentration: 99 nM
Estimate against measurement, compound 3: 1.3-fold (0.12 log units) above, and the stated range covers the measured number.
By their numbers in this assay, from the lowest: compounds 3, 1 and 2 (each within the scatter of the next).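

In this assay, 2H-tetrazol-2-yl in place of 1H-pyrazol-1-yl gives a 1.1-fold lower number from compound 2 to compound 3 (0.06 log units; within the scatter), and the same group in place of pyridin-4-yl gives a 1.0-fold lower number from compound 1 to compound 3 (0.02 log units; within the scatter). The earlier compounds shown here showed one exchange between a six-membered and a five-membered aromatic ring; this result adds a second five-membered ring with 4 hetero atoms and 4 hydrogen-bond acceptors, against 2 of each in 1H-pyrazol-1-yl. At this place, para to a large group, all three aromatic groups thus lie within the scatter of one another, and the added hetero atoms bring no step beyond it.

On these data alone, whether a group of another kind at this place, such as an amine, a carboxylic acid or a longer alkyl chain, would hold the number in this range stays open. Nothing shown explains why these three groups read alike.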